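A few compounds are considered here, and "the series" means these few. Any claim that something is new, unique, unknown or untested is made for them only; others in the source may bear on it.

Of the compounds shown here, three built on a shared core have been tested in a functional assay on CHO cells with adenosine receptor A1 (Homo sapiens) as the target, read by cAMP accumulation and immunoassay, with a stated time of 6 min, tested at 0.01 uM; on this read-out higher numbers stand for a weaker effect at the one concentration tested and lower numbers for a stronger effect. Compound 1 `Nc1scc(CN2CCN(c3ccc([N+](=O)[O-])cc3)CC2)c1C(=O)c1ccc(Cl)cc1` gives -12% in this assay. Compound 2 `Nc1scc(CN2CCC(c3ccc(Cl)cc3)CC2)c1C(=O)c1ccc(Cl)cc1` gives 0%, and compound 3 `Nc1scc(CN2CCN(c3cccc(F)c3)CC2)c1C(=O)c1cccc(C(F)(F)F)c1` gives -11%. Among these three numbers compound 1 sits at the low end: the number of compound 3 lies within the usual scatter of it, while the number of compound 2 lies beyond the scatter, on the higher side.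

Compound 4 `Nc1scc(CN2CCN(C3CCCCCC3)CC2)c1C(=O)c1ccc(Cl)cc1` has not yet been measured. It differs from compound 1 in one place: cycloheptyl in place of 4-nitrophenyl on an amine nitrogen in a ring. Going by the values given here, no pair of measured compounds differs by a single change, so nothing measured tells how this change should run. All three measured numbers lie close to no effect at the concentration used, so a small step is expected, with no direction beyond the scatter, a number 6 percentage points higher from compound 1 to compound 4 (within the scatter). Compound 4 is therefore expected to give about -6% in this assay, within a range from -22% to 10%.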

Compound 4, a percentage reported as activity, at one concentration (the size of the read-out at that concentration, not a potency): 2.9%
Estimate against measurement, compound 4: 8.9 percentage points below; the measured number falls inside the stated range.
By their numbers in this assay, from the lowest: compounds 1 and 3 (each within the scatter of the next); then compounds 2 and 4 (each within the scatter of the next).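

Going by these compounds alone, the swap of 4-nitrophenyl for cycloheptyl on the amine nitrogen gives the only single-change step on the shared core: in this assay the number moves a number 14.9 percentage points higher from compound 1 to compound 4 (beyond the scatter) and stays close to no effect at the one concentration tested. The read-out at this position therefore responds to the group on this nitrogen, although the step is modest. Nothing available on the properties of these groups accounts for the step.

This one step replaces the nitro group, the aromatic ring and the ring size together, so it cannot show which of these changes matters. As far as these compounds go, whether a plain phenyl or a cyclohexyl on the same nitrogen would stand nearer compound 1 or compound 4 stays open, as does the effect of either group at other concentrations.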